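Swapping a Methyl for Hydrogen on Compound 2

The compounds below may be only part of what the source reports. "The series", "measured", "known", "first", "only" and "open" are said of these compounds alone.

In a functional assay on Bel-7402 cells (Homo sapiens) for antiproliferative activity, read by MTT assay, with a stated time of 72 h (a lower number here means a stronger inhibitor, a higher number a weaker inhibitor), compound 1 `COc1cccc(CNCc2c(C(=O)O)n(Cc3ccccc3F)c3cc(C)ccc23)c1` gives > 50000 nM, which is a limit and not a number. Among the compounds with values here, compound 2 `COc1ccc(Cn2c(C(=O)O)c(CNCc3cccc(OC)c3)c3ccc(C)cc32)cc1` gives 9830 nM, the only true number so far. Within the data shown here, the single measured step, an at least 5.0-fold lower number from compound 1 to compound 2 (0.70 log units; beyond the scatter), altered the same aromatic ring that changes next, so it is the one guide available. Compound 3 `COc1cccc(CNCc2c(C(=O)O)n(Cc3ccc(O)cc3)c3cc(C)ccc23)c1` carries hydrogen in place of methyl on an oxygen on an aromatic ring, which turns 4-methoxybenzyl into 4-hydroxybenzyl. This edit is smaller than that earlier swap, so in this assay the expected result is a shift within the scatter, leaning weaker: a 1.3-fold higher number from compound 2 to compound 3 (0.12 log units; within the scatter). Compound 3 is estimated at 13000 nM, within a range of 5000 nM to 40000 nM.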

Compound 3, half-maximal inhibitory concentration: > 50000 nM
Compound 3 was reported as a limit; the forecaster's own chance of this, stated with the estimate: 20%; middle value at least 3.8-fold (0.58 log units) away from the limit.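

Even the smallest edit counts at this position: taking only the methyl off the 4-methoxybenzyl group gives an at least 5.0-fold higher number from compound 2 to compound 3 (0.70 log units; beyond the scatter) in this assay. The value of compound 3 is a limit and not a number. The step between compound 1 and compound 3 cannot be read: the limit of > 50000 nM in this assay, at which 2 of the 3 values shown sit.

Still open, going by these compounds, is whether a longer chain on the oxygen, as in ethoxy, would keep the value of compound 2. Also open, on these data alone, is what an amine in place of the methoxy would do.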